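The source may report more compounds than this note shows. Statements on the series, on what has been measured and on what is new or still open speak of the compounds shown alone.

For the measured compounds named here, compound 2, `COc1ccc2nc(C)cc(OCC(=O)Nc3ccccc3)c2c1`, is one of two compounds measured in a physicochemical assay for solubility, in phosphate buffer, measured as kinetic solubility, with a stated time of 1 h, at pH 7.4; a lower number here means a less soluble compound, a higher number a more soluble compound. In this assay compound 2 gives 63000 nM. The other measured compound is compound 1, `COc1ccc2nc(C)cc(OCCNc3cc(C)cc(C)c3)c2c1`, which in this assay gives 33000 nM. Compound 2 has the higher of the two numbers, yet the gap to compound 1 lies within the scatter of the measurement, so the two cannot be told apart on this evidence.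

The step under consideration leads from compound 2 to compound 3, `COc1ccc2nc(C)cc(OCC(=O)Nc3c(C)cncc3C)c2c1`, which has not yet been measured. The structural change is 3,5-dimethylpyridin-4-yl in place of phenyl on an amide-type nitrogen. Going by the values given here, no step between two measured compounds resembles this change, so the expectation rests on the two numbers alone and on the change itself.

Compound 3 is expected to show a modest rise, a 1.6-fold higher number from compound 2 to compound 3 (0.20 log units; within the scatter), in this assay. The estimate for compound 3 in this assay is 100000 nM, with a range from 40000 nM to 250000 nM.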

Compound 3, solubility: 12000 nM
The estimate for compound 3 lay 8.3-fold (0.92 log units) above the measured number; measured number outside the range, below it.
By their numbers in this assay, from the lowest: compound 3; then compounds 1 and 2 (each within the scatter of the next).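

For the compounds shown here, the position on the amide-type nitrogen proves sensitive in this assay where the earlier compounds could show nothing: 3,5-dimethylpyridin-4-yl in place of phenyl gives a 5.3-fold lower number from compound 2 to compound 3 (0.72 log units; beyond the scatter) and thus the only step that stands beyond the scatter. The entering group carries a hydrogen-bond acceptor that phenyl lacks, and here the number still falls, so that count alone does not go with a higher number in this pair. Nothing at hand explains the step.

The compounds shown leave open whether the ring nitrogen or the two methyl groups account for the step, as both enter together. Also open, on these data alone, is how plain pyridin-4-yl, 3,5-dimethylphenyl, or a group bearing an amine or a carboxylic acid would read on this nitrogen.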